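The source may report more compounds than this note shows. Statements on the series, on what has been measured and on what is new or still open speak of the compounds shown alone.

Measured:
compound 1 `COc1ccc(C(=O)Nc2nc(C)c(C(=O)/C=C/c3ccc(F)cc3)s2)cc1` — 88.2%
compound 2 `Cc1ccc(/C=C/C(=O)c2sc(NC(=O)c3ccc(F)cc3)nc2C)cc1` — 91.5%

In an assay for inhibition of Polyunsaturated fatty acid 5-lipoxygenase (Homo sapiens), read by spectrophotometry, tested at 10 uM, in the presence of a further agent that is not named here (a higher number here means more inhibition at the concentration tested (going by the name of the read-out), a lower number less inhibition), compound 1 gives 88.2%, and compound 2 gives 91.5%; the two numbers lie within the usual scatter of each other, so neither compound can be set apart from the other on these data. Compound 3 `COc1ccc(C(=O)Nc2nc(C)c(C(=O)/C=C/c3ccc(C)cc3)s2)cc1` differs from compound 2 in one place: methoxy in place of fluoro on an aromatic carbon. Among the compounds with values here, no measured pair covers this change alone. The step of a number 2.5 percentage points lower from compound 2 to compound 3 (within the scatter) is expected to stay within the scatter, with no clear direction. Compound 3 is therefore estimated at 89% in this assay, in the range 78% to 96%.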

Compound 3, a percentage reported as inhibition, at one concentration (the size of the read-out at that concentration, not a potency): 100%
Beside the measured number, compound 3's estimate is 11 percentage points below it, outside the stated range (above it).
By their numbers in this assay, from the lowest: compounds 1, 2 and 3 (each within the scatter of the next, the first and the last beyond it).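

In this assay methoxy in place of fluoro at this position gives a number 8.5 percentage points higher from compound 2 to compound 3 (within the scatter) and so shows that the larger group is accepted here without a readable change. Methyl in place of fluoro on a different aromatic carbon gives a number 11.8 percentage points higher from compound 1 to compound 3 (beyond the scatter) and is the only step shown beyond the scatter, though it rests on a single pair. Nothing measured here accounts for either step.

Going by these compounds, whether an amine or a carboxylic acid at this position would keep the inhibition remains open. Inhibition at one concentration also leaves the potency of these compounds unresolved.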